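The compounds below may be only part of what the source reports. "The series", "measured", "known", "first", "only" and "open" are said of these compounds alone.

Among the compounds with values here, compound 2 `Cc1cc(C)c2sc(NC(=O)c3ccc(C#N)cc3)nc2c1` is the only member of this set with a measured number: in a functional assay on NUGC-3 cells (Homo sapiens) for antiproliferative activity, read by sulforhodamine B assay (a higher number here means a weaker inhibitor of growth, a lower number a stronger inhibitor of growth), compound 2 gives 0.62 ug/mL. Compound 1 `COc1ccc(C(=O)Nc2nc3cc(C)cc(C)c3s2)cc1` reaches only the limit of this assay, giving > 10 ug/mL. Compound 3 `COc1cccc2sc(NC(=O)c3ccc([N+](=O)[O-])cc3)nc12` likewise stops at the limit, giving > 10 ug/mL. Within the data shown here, the one measured step, an at least 16-fold lower number from compound 1 to compound 2 (1.20 log units; beyond the scatter), is large. Compound 4 `Cc1cc(C)c2sc(NC(=O)c3ccc([N+](=O)[O-])cc3)nc2c1` differs from compound 2 by nitro in place of cyano on an aromatic carbon. Among the measured compounds shown here, no measured step exchanges nitro for cyano, and the nitro analogue compound 3 is on a different core and sits at the limit of > 10 ug/mL in this assay, at which 2 of the 3 values shown sit, so it offers no size for the step. Compound 4 is therefore expected to stay close to compound 2, with the step from compound 2 to compound 4 expected to be a 1.6-fold higher number from compound 2 to compound 4 (0.21 log units; within the scatter), inside the scatter. The estimate for compound 4 is 1 ug/mL, between 0.3 ug/mL and 4 ug/mL.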

Compound 4, concentration for 50% growth inhibition: 1.32 ug/mL
Estimate against measurement, compound 4: 1.3-fold (0.12 log units) below; the range from low to high includes it.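

Nitro in place of cyano gives a 2.1-fold higher number from compound 2 to compound 4 (0.33 log units; beyond the scatter), so at this position, para to a large group, the two groups are separated by a modest step on the shared core. Nitro in place of methoxy gives an at least 7.5-fold lower number from compound 1 to compound 4 (0.87 log units; beyond the scatter), so nitro, like cyano, stands clearly apart from methoxy here. That step remains only a bound, because compound 1 reaches a limit of the assay: the limit of > 10 ug/mL in this assay, at which 2 of the 4 values shown sit.

As far as these compounds go, how an amine, a carboxylic acid or a chlorine atom would behave at this position remains open. From the compounds shown here alone, the true distance between methoxy and nitro also remains unknown.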